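Chloro added to the phenyl of compound 3

This account rests on a few compounds, and the source may have more. Where it says the series, first, only, none or still open, it means among the compounds named here.

Among the compounds with values here, compound 3 `Cc1cc(C)nc(NS(=O)(=O)c2ccc(N3C(=O)/C(=C/c4coc5ccccc5c4=O)N=C3c3ccccc3)cc2)n1` is the one member of this small set for which a number rather than a limit has been read: in a functional assay on MCF7 cells (Homo sapiens) for cytotoxicity, read by sulforhodamine B assay, with a stated time of 72 h (on this read-out lower numbers stand for stronger inhibition and higher numbers for weaker inhibition), compound 3 gives 99700 nM. Compound 1 `O=C1/C(=C/c2coc3ccccc3c2=O)N=C(c2ccc(Cl)cc2)N1c1ccc(S(=O)(=O)Nc2ncccn2)cc1` reaches only the limit of the assay, and in this assay compound 1 gives > 100000 nM, which is a limit. Compound 2 `O=C1/C(=C/c2coc3ccccc3c2=O)N=C(c2ccc(Cl)cc2)N1c1ccc(S(=O)(=O)Nc2nccs2)cc1` likewise sits at a limit, giving > 100000 nM in this assay. The step from compound 1 to compound 2, a step that the two limits leave unreadable from compound 1 to compound 2, changes the heterocycle on the sulfonamide nitrogen, and its size cannot be read because both of its ends sit at the limit of > 100000 nM in this assay, at which 2 of the 3 values shown sit.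

Compound 4 `Cc1cc(C)nc(NS(=O)(=O)c2ccc(N3C(=O)/C(=C/c4coc5ccccc5c4=O)N=C3c3ccc(Cl)cc3)cc2)n1` differs from compound 3 by chloro in place of hydrogen on an aromatic carbon. Within the data shown here, no measured pair here alters that phenyl ring, so no measured step bears directly on this change; the one step in the set concerns a different part of the molecule and is itself unreadable. The expected step from compound 3 to compound 4 in this assay is therefore a 1.0-fold higher number from compound 3 to compound 4 (0.00 log units; within the scatter), with no change beyond the scatter anticipated in either direction. Compound 4 is thus estimated at 100000 nM in this assay, within 50000 nM to 200000 nM.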

Compound 4, half-maximal inhibitory concentration: 93900 nM
Compound 4: the middle estimate sits 1.1-fold (0.03 log units) above what was measured, within the range that was stated.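

The step from compound 3 to compound 4 gives this position its first readable measure: chloro in place of hydrogen on an aromatic carbon, para to a large group, amounts in this assay to a 1.1-fold lower number from compound 3 to compound 4 (0.03 log units; within the scatter), so the change from phenyl to 4-chlorophenyl leaves the read-out within the scatter. Compound 4 also gives the 4-chlorophenyl compounds a number rather than a limit, so that the change of heterocycle on the sulfonamide nitrogen can be set against it, as an at least 1.0-fold lower number from compound 2 to compound 4 (0.02 log units; that floor lies within the scatter) and as an at least 1.0-fold lower number from compound 1 to compound 4 (0.02 log units; that floor lies within the scatter). These two steps are floors only, and neither shows a change beyond the scatter: the limit of > 100000 nM in this assay, at which 2 of the 4 values shown sit.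

The compounds shown leave open whether another group at this place on the phenyl, such as methoxy, an amine or a carboxylic acid, would move the number in this assay. Also open, going by these compounds, is what the same read-out would give with a plain hydrogen or an acetyl group on the sulfonamide nitrogen in place of the heterocycle.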